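This account rests on a few compounds, and the source may have more. Where it says the series, first, only, none or still open, it means among the compounds named here.

Compound 1 `CCn1cnc2c(NC(=N)N)nc(N)nc21`, compound 2 `Cn1cnc2c(NC(=N)N)ncnc21` and compound 3 `CC(C)n1cnc2c(NC(=N)N)nc(NCCO)nc21` share a core that carries a guanidine and differ in the alkyl on the ring nitrogen and in the group on the six-membered aromatic ring with 2 nitrogen. All three have been tested in a functional assay on MCF7 cells (Homo sapiens) for inhibition, read by fluorescence, with a stated time of 72 h; a lower number here means a stronger inhibitor, a higher number a weaker inhibitor. Compound 3 gives 12400 nM in this assay, the lowest of the two numbers reported. Compound 1 gives 54300 nM in this assay, a gap from compound 3 that lies beyond the usual scatter of repeated measurements. Among the measured compounds shown here, for compound 2 this assay reports no number but a limit, > 100000 nM; it is the one value sitting at the limit of > 100000 nM in this assay, at which 1 of the 3 values shown sits.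

Compound 4 `CC(C)n1cnc2c(NC(=N)N)nc(OC[C@@H]3CCCN3)nc21` has not yet been measured. It differs from compound 3 in one place, ((pyrrolidin-2-yl)methoxy in place of (2-hydroxyethyl)amino on an aromatic carbon). For the measured compounds named here, no two of the measured compounds differ in a single place, so no measured step shows what such an exchange does in this assay, and the expectation rests on compound 3 alone. The step is expected to be a modest gain in potency, a 2.1-fold lower number from compound 3 to compound 4 (0.32 log units; beyond the scatter), since compound 3 already stands at 12400 nM. Compound 4 is therefore estimated at 6000 nM, with a range from 1500 nM to 25000 nM.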

Compound 4, half-maximal inhibitory concentration: > 100000 nM
Compound 4: a limit, no number (the forecaster's own chance of this, stated with the estimate: 10%); at least 16-fold (1.22 log units) between middle value and limit.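

On the aromatic carbon between two ring nitrogen atoms, the group is not interchangeable: in this assay, putting (pyrrolidin-2-yl)methoxy in place of (2-hydroxyethyl)amino gives an at least 8.0-fold higher number from compound 3 to compound 4 (0.90 log units; beyond the scatter). From the compounds shown here alone, the value of compound 4 is a limit of the assay and not a number, so this step marks only the smallest size the loss can have, and how weak compound 4 really is stays unknown. This single exchange is the first direct reading at this position, and it adds a second compound to the top of the range that can be read: the limit of > 100000 nM in this assay, at which 2 of the 4 values shown sit.

The exchange changes the linking atom from nitrogen to oxygen and also brings in the pyrrolidine ring, and the compounds shown do not separate the two; a 2-hydroxyethoxy group or a (pyrrolidin-2-yl)methylamino group on this carbon would pull them apart. Also open, going by these compounds, is how the opposite configuration at the defined stereocentre, or a longer chain such as (3-hydroxypropyl)amino, would read in this assay.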